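Chain methyl removal in a quinone sulfonyl series

This account rests on a few compounds, and the source may have more. Where it says the series, first, only, none or still open, it means among the compounds named here.

Three compounds are measured in a functional assay on A549 cells (Homo sapiens) for inhibition, read by MTT assay, with a stated time of 72 h; a higher number here means a weaker inhibitor, a lower number a stronger inhibitor. Compound 1 `CC1=C(C(C)CC(=O)OCCCCOc2no[n+]([O-])c2S(=O)(=O)c2ccccc2)C(=O)c2c(O)cccc2C1=O` gives 19600 nM. Compound 2 `CC1=C(C(C)CC(=O)OCC(C)COc2no[n+]([O-])c2S(=O)(=O)c2ccccc2)C(=O)c2c(O)cccc2C1=O` gives 12800 nM, and compound 3 `CC1=C(CCC(=O)OCCOc2no[n+]([O-])c2S(=O)(=O)c2ccccc2)C(=O)c2c(O)cccc2C1=O` gives 9310 nM. Compound 2 stands second highest of the three numbers, but its gaps to compound 3 and to compound 1 both lie within the scatter, so no ranking among the three can be read.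

Compound 4 `CC1=C(CCC(=O)OCC(C)COc2no[n+]([O-])c2S(=O)(=O)c2ccccc2)C(=O)c2c(O)cccc2C1=O` is not yet measured in this assay. It differs from compound 2 by hydrogen in place of methyl on a saturated chain carbon bound to a double-bonded ring carbon and a saturated chain carbon. For the measured compounds named here, no measured pair isolates this change. Compound 3, which also carries hydrogen at that carbon, gives 9310 nM, close to compound 2, so no step beyond the scatter is expected here. Compound 4 is expected to give 10500 nM, with a range from 4500 nM to 25000 nM. The expected step is a 1.2-fold lower number from compound 2 to compound 4 (0.09 log units; within the scatter), within the scatter.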

Compound 4, half-maximal inhibitory concentration: 18200 nM
For compound 4 the middle estimate is 1.7-fold (0.24 log units) below the measured one; the measured number falls inside the stated range.
By their numbers in this assay, from the lowest: compounds 3, 2, 4 and 1 (each within the scatter of the next, the first and the last beyond it).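

For the compounds shown here, compound 2 and compound 4 give the first pair that isolates hydrogen in place of methyl on this saturated chain carbon, and the step, a 1.4-fold higher number from compound 2 to compound 4 (0.15 log units; within the scatter), shows that in this assay the methyl makes no difference that can be read beyond the scatter. With the chain ending held constant, this carbon therefore tolerates either hydrogen or methyl in this pair.

From the compounds shown here alone, whether an ethyl group or an amine at this carbon would give a step beyond the scatter stays open, as does the same hydrogen-for-methyl replacement in compound 1. No supporting data bear on what lies behind this reading.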